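The source may report more compounds than this note shows. Statements on the series, on what has been measured and on what is new or still open speak of the compounds shown alone.

Measured compounds:
Compound 1, `O=C1OCC[C@@H]1NC(=S)SCCOc1ccc([N+](=O)[O-])cc1`, in a functional assay on PC-3 cells (Homo sapiens) for antiproliferative activity, read by MTT assay, with a stated time of 72 h; on this read-out higher numbers stand for weaker inhibition and lower numbers for stronger inhibition: 32500 nM.
Compound 2, `CC(=O)c1ccc(OCCSC(=S)N[C@H]2CCOC2=O)cc1`, in this assay: 46900 nM.

Among the compounds with values here, compound 2 cannot be set apart from compound 1 in this assay: the only measured step, a 1.4-fold higher number from compound 1 to compound 2 (0.16 log units; within the scatter), is within the scatter, so the two numbers stand together and nothing separates them. Compound 3, `O=C1OCC[C@@H]1NC(=S)SCCOc1ccc(Cl)cc1`, has not yet been measured in this assay. It differs from compound 2 in one place: chloro in place of acetyl on an aromatic carbon. Within the data shown here, the one measured step that bears on this is the same kind of exchange at the position para to the large group, and that step, a 1.4-fold higher number from compound 1 to compound 2 (0.16 log units; within the scatter), stayed within the scatter. On that basis compound 3 is expected to stay close to compound 2 in this assay, with no step beyond the scatter, the expected step being a 1.2-fold lower number from compound 2 to compound 3 (0.07 log units; within the scatter). The estimate for compound 3 in this assay is therefore 40000 nM, with a range from 15000 nM to 110000 nM.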

Compound 3, half-maximal inhibitory concentration: > 64000 nM
Compound 3 was reported as a limit (the forecaster's own chance of this, stated with the estimate: 15%); at least 1.6-fold (0.20 log units) between middle value and limit.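

Of the three groups at this position, para to a large group, only chloro takes the read-out in this assay to a limit and not to a number: the limit of > 64000 nM in this assay, at which 1 of the 3 values shown sits.

The steps that follow are therefore floors only (an at least 1.3-fold higher number from compound 2 to compound 3 (0.13 log units; that floor lies within the scatter)) and (an at least 1.9-fold higher number from compound 1 to compound 3 (0.29 log units; that floor lies within the scatter)), so the real size of each could lie within the scatter or beyond it. The change to chloro thus gives no sign of stronger inhibition than acetyl or nitro on this aromatic carbon.

The compounds shown leave open how far compound 3 really stands from compound 1 and compound 2, since neither step has an upper end. They also leave open whether an amine or a carboxylic acid on this aromatic carbon would move the number beyond the scatter in either direction.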